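Benzyl for amino on the imine nitrogen of compound 3

The source may report more compounds than this note shows. Statements on the series, on what has been measured and on what is new or still open speak of the compounds shown alone.

The series rests on a shared core carrying a double-bonded nitrogen, and all three measured members were read in a functional assay, read by spectrophotometry, with a stated time of 1 h; a lower number here means a stronger inhibitor, a higher number a weaker inhibitor. Compound 1 `O=c1[nH]c2ccccc2cc1/C=N/Cc1ccccc1` gives 3140000 nM. Compound 2 `Cc1ccc2[nH]c(=O)c(/C=N/O)cc2c1`, which bears a ring methyl, gives 1980000 nM. Compound 3 `Cc1ccc2[nH]c(=O)c(/C=N/N)cc2c1` gives 790000 nM, the lowest of the three numbers and thus the strongest inhibitor so far; the step of a 2.5-fold lower number from compound 2 to compound 3 (0.40 log units; beyond the scatter) separates it from compound 2, and compound 1 lies further off still.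

Compound 4 `Cc1ccc2[nH]c(=O)c(/C=N/Cc3ccccc3)cc2c1` is not yet measured. Relative to compound 3 it shows (benzyl in place of amino on a double-bonded nitrogen). For the measured compounds named here, no measured step covers this exact exchange, but compound 1, the benzyl analogue lacking the methyl, shows 3140000 nM against compound 3 at 790000 nM, and the one measured step, a 2.5-fold lower number from compound 2 to compound 3 (0.40 log units; beyond the scatter), shows that the group on the double-bonded nitrogen moves the number modestly. Compound 4 is therefore expected to rise by a 3.2-fold higher number from compound 3 to compound 4 (0.50 log units; beyond the scatter), landing near compound 1. The estimate for compound 4 is 2500000 nM, within 900000 nM to 7000000 nM.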

Compound 4, half-maximal inhibitory concentration: 6920000 nM
Beside the measured number, compound 4's estimate is 2.8-fold (0.44 log units) below it; the range from low to high includes it.
By their numbers in this assay, from the lowest: compound 3; then compounds 2 and 1 (each within the scatter of the next); then compound 4.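

In this assay, putting benzyl on the double-bonded nitrogen gives an 8.8-fold higher number from compound 3 to compound 4 (0.94 log units; beyond the scatter) when it replaces amino, and a 3.5-fold higher number from compound 2 to compound 4 (0.54 log units; beyond the scatter) when it replaces hydroxy, so the earlier modest step between those two groups is not the largest change this position can show. Compound 4 is the weakest inhibitor of the four, with its steps to all the others beyond the scatter. For the compounds shown here, the series also now isolates the ring methyl for the first time: with benzyl held on the nitrogen, methyl in place of hydrogen on an aromatic carbon gives a 2.2-fold higher number from compound 1 to compound 4 (0.34 log units; beyond the scatter) in the same direction, so that change is not neutral in this pair. Nothing shown gives a reason for these shifts.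

Going by these compounds, it remains open whether a plain ethyl chain or a phenyl group on the double-bonded nitrogen would fall nearer amino or benzyl. On these data alone, it is also open whether the ring methyl moves the number the same way when amino or hydroxy sits on that nitrogen.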